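The source may hold more compounds than are shown below. What is called first, only, known or untested is meant among the compounds shown, and "the series" means these compounds.

In a functional assay on Rec1 cells (Homo sapiens) for inhibition, read by luminescence and CellTiter-Glo, with a stated time of 72 h (on this read-out higher numbers stand for weaker inhibition and lower numbers for stronger inhibition), compound 1 `CCOC(=O)c1cc(-c2ccc(Oc3ccccc3)cc2)nn1Cc1cccc(NC(=O)CCl)c1` gives 400 nM and compound 2 `C=CC(=O)Nc1ccc(Cn2nc(-c3ccc(Oc4ccccc4)cc3)cc2C(=O)OCC)cc1` gives 2800 nM. Among the compounds with values here, the step of a 7.0-fold higher number from compound 1 to compound 2 (0.85 log units; beyond the scatter) is the only single-place change measured so far. Compound 3 `C/C=C/C(=O)Nc1cccc(Cn2nc(-c3ccc(Oc4ccccc4)cc3)cc2CO)c1` gives 3400 nM, within the scatter of compound 2 and, beyond the scatter, a higher number than compound 1.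

Compound 4 `C/C=C/C(=O)Nc1cccc(Cn2nc(-c3ccc(Oc4ccccc4)cc3)cc2C(=O)OCC)c1` differs from compound 3 as follows: ethoxycarbonyl in place of hydroxymethyl on an aromatic carbon. This puts ethoxycarbonyl in place of hydroxymethyl on an aromatic carbon, next to the ring nitrogen. Within the data shown here, the one measured step changes the other end of the molecule, so no measured step isolates this change and its size does not carry over. Compound 4 shares the ethoxycarbonyl of compound 2, which gives 2800 nM, and of compound 1, which gives 400 nM. These two values support only a slight lean towards a lower number in this assay, and no change beyond the scatter is expected. The expected size is a 1.7-fold lower number from compound 3 to compound 4 (0.23 log units; within the scatter). For compound 4 the estimated value is 2000 nM, with an expected range of 700 nM to 5500 nM.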

Compound 4, half-maximal inhibitory concentration: 7800 nM
The estimate for compound 4 lay 3.9-fold (0.59 log units) below the measured number; measured number above the stated range.
By their numbers in this assay, from the lowest: compound 1; then compounds 2 and 3 (each within the scatter of the next); then compound 4.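

Ethoxycarbonyl in place of hydroxymethyl on this aromatic carbon now has a measured size in this assay: a 2.3-fold higher number from compound 3 to compound 4 (0.36 log units; beyond the scatter) with the 3-(((prop-1-en-1-yl)carbonyl)amino)phenyl group held constant, so hydroxymethyl gives the stronger inhibition in this pair. With ethoxycarbonyl held constant, the other end of the molecule also matters: the step of a 2.8-fold higher number from compound 2 to compound 4 (0.44 log units; beyond the scatter) accompanies the change from 4-((vinylcarbonyl)amino)phenyl to 3-(((prop-1-en-1-yl)carbonyl)amino)phenyl, while the large step of a 20-fold higher number from compound 1 to compound 4 (1.29 log units; beyond the scatter) accompanies prop-1-en-1-yl in place of chloromethyl on a carbonyl carbon. Nothing available explains either the direction or the size of these steps.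

As far as these compounds go, whether hydroxymethyl would also give a lower number alongside the chloromethyl carbonyl group remains open. So does the effect of a carboxylic acid or an aminomethyl group on this aromatic carbon.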